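A few compounds are considered here, and "the series" means these few. Any claim that something is new, unique, unknown or untested is made for them only; others in the source may bear on it.

Working notes on the series.

For the measured compounds named here, compound 1 `CC(C)=CCNC(=N)NCCCCCCN` gives the lowest number of the two measured so far: in an assay on isolated protein for inhibition of polyamine oxidase 1 (Zea mays), read by spectrophotometry, using a Dixon plot, at pH 6.5 (on this read-out lower numbers stand for stronger inhibition and higher numbers for weaker inhibition), compound 1 gives 22 nM. Going by the values given here, the only other measured member, compound 2 `N=C(NCCCCN)Nc1ccc(F)cc1`, gives 630 nM in this assay, a gap that lies beyond the scatter; the two structures differ in more than one place, so no single step can be drawn between them.

Compound 3 `CC(C)=CCNC(=N)NCCCCNC(=N)N` has not yet been measured. Relative to compound 1 the change is a group of 4 heavy atoms (1 carbon, 3 nitrogen; no ring) in place of a group of 3 heavy atoms (2 carbon, 1 nitrogen; no ring), on a saturated chain carbon, four bonds along the chain from an amine nitrogen. Among the compounds with values here, no measured pair in the set isolates this change, so its effect can only be guessed. The expectation for compound 3 is a weakening in this assay that is modest and may not exceed the scatter, a step of a 2.7-fold higher number from compound 1 to compound 3 (0.44 log units; beyond the scatter). Compound 3 is accordingly expected to give about 60 nM in this assay, with a plausible range from 15 nM to 300 nM.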

Compound 3, inhibition constant: 700 nM
Estimate against measurement, compound 3: 12-fold (1.07 log units) below; measured number outside the range, above it.
By their numbers in this assay, from the lowest: compound 1; then compounds 2 and 3 (each within the scatter of the next).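

In this assay, the place on the saturated chain carbon, four bonds along the chain from an amine nitrogen, proves sensitive: putting the group of 4 heavy atoms (1 carbon, 3 nitrogen) in place of 2-aminoethyl gives a 32-fold higher number from compound 1 to compound 3 (1.50 log units; beyond the scatter) in this read-out. For the compounds shown here, this is the first step that isolates a single place, and it shows that this exchange, which takes the group from 1 hydrogen-bond donor to 3, is not tolerated without a large rise in the number. Nothing measured here bears on the reason for this step.

On these data alone, whether a longer chain ending in an amine, or a carboxylic acid at the same place, would keep the number near that of compound 1 remains open. Also open, as far as these compounds go, is whether the same exchange on the core of compound 2 would bring a step of similar size.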